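Oxime ether variations on a shared core: lipophilicity notes

The source may report more compounds than this note shows. Statements on the series, on what has been measured and on what is new or still open speak of the compounds shown alone.

Measured compounds in a physicochemical assay for lipophilicity, using the shake flask method; on this read-out lower numbers stand for lower lipophilicity and higher numbers for higher lipophilicity:
- Compound 1, `C=CCO/N=C/c1c(N)ncnc1Oc1ccc(NC(=O)C2(C(=O)Nc3ccc(F)cc3)CC2)cc1F`: 3.65
- Compound 2, `Nc1ncnc(Oc2ccc(NC(=O)C3(C(=O)Nc4ccc(F)cc4)CC3)cc2F)c1/C=N/O`: 2.62
- Compound 3, `C#CCO/N=C/c1c(N)ncnc1Oc1ccc(NC(=O)C2(C(=O)Nc3ccc(F)cc3)CC2)cc1F`: 3.34

Compound 3 stands second highest of the three numbers in this assay. Its nearest neighbour is compound 1, where the step reads a number 0.31 log units lower from compound 1 to compound 3 (beyond the scatter); the furthest is compound 2, where the step reads a number 0.72 log units higher from compound 2 to compound 3 (beyond the scatter). The step of a number 1.03 log units lower from compound 1 to compound 2 (beyond the scatter) shows how much the free oxime sits below the allyl ether.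

Compound 4, `Nc1ncnc(Oc2ccc(NC(=O)C3(C(=O)Nc4ccc(F)cc4)CC3)cc2F)c1/C=N/OC1CCCCC1`, differs from compound 3 by cyclohexyl in place of propargyl on an oxygen. For the measured compounds named here, two measured steps bear on this change, both between hydrogen on the same oxygen and a carbon chain. One is a number 0.72 log units higher from compound 2 to compound 3 (beyond the scatter). The other, larger one is a number 1.03 log units lower from compound 1 to compound 2 (beyond the scatter), read in reverse. Cyclohexyl brings more carbon than either allyl or propargyl and no ring was present in the leaving group, so the step in this assay is expected to be upward and larger than either measured step. The expected step is a number 1.36 log units higher from compound 3 to compound 4 (beyond the scatter). Compound 4 is therefore estimated at 4.7, with a range from 4.1 to 5.3.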

Compound 4, partition coefficient: 4.69
The estimate for compound 4 lay 0.01 log units above the measured number; the measured number falls inside the stated range.
By their numbers in this assay, from the lowest: compound 2; then compound 3; then compound 1; then compound 4.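

Cyclohexyl on this oxygen, the only ring among the groups compared here, moves the number in this assay further than exchanging one open chain for another had done: the step is a number 1.35 log units higher from compound 3 to compound 4 (beyond the scatter), and against the allyl ether it is a number 1.04 log units higher from compound 1 to compound 4 (beyond the scatter). For the compounds shown here, both are large, whereas the earlier step between the two open-chain ethers was only modest, so the choice of ether group at this position can shift the read-out by far more than the earlier compounds showed. The full span from the free oxime is a number 2.07 log units higher from compound 2 to compound 4 (beyond the scatter), which places compound 4 highest of the four in this assay, with its steps to all the others beyond the scatter. No measurement at hand accounts for the size of these steps.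

The compounds shown do not separate the effect of the ring from that of the carbon count in cyclohexyl, and what an open hexyl chain would give on this oxygen stays open. Equally open, from the compounds shown here alone, is where a chain ending in an amine or a carboxylic acid would fall.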